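Replacing the 4-(dimethylcarbamoyl)-1H-pyrazol-1-yl group of compound 2

The source may report more compounds than this note shows. Statements on the series, on what has been measured and on what is new or still open speak of the compounds shown alone.

Measured in a physicochemical assay for lipophilicity, using the shake flask method, at pH 7.4 (on this read-out higher numbers stand for higher lipophilicity and lower numbers for lower lipophilicity), so far
compound 1 `CCCC(Nc1ccc(-n2cc(C(F)(F)F)cn2)nc1)c1ccc(C(=O)NCCC(=O)O)cc1` gives 2.1
compound 2 `CCCC(Oc1ccc(-n2cc(C(=O)N(C)C)cn2)cc1)c1ccc(C(=O)NCCC(=O)O)cc1` gives 0.5
compound 3 `CCCC(Nc1cc(C)c(-n2cc(C(F)(F)F)cn2)c(C)c1)c1ccc(C(=O)NCCC(=O)O)cc1` gives 2.2

Compound 2 (0.5) stands lowest of the three, beyond the scatter from both others. Compound 4 `CCCC(Oc1ccc(-n2cc3c(n2)CCCC3)cc1)c1ccc(C(=O)NCCC(=O)O)cc1` departs from it by one change a group of 9 heavy atoms (7 carbon, 2 nitrogen; one five-membered aromatic ring with 2 hetero atoms, one six-membered non-aromatic ring of carbon only) in place of a group of 10 heavy atoms (6 carbon, 3 nitrogen, 1 oxygen; one five-membered aromatic ring with 2 hetero atoms), on an aromatic carbon and this falls on an aromatic carbon, para to a large group. Within the data shown here, no measured pair shows this change alone. The expectation leans on compound 1 (2.1) and compound 3 (2.2), neither of which carries the dimethylcarbamoyl group. A rise in this assay beyond the scatter is expected, estimated as a number 1.70 log units higher from compound 2 to compound 4 (beyond the scatter) in size. For compound 4 the estimated value is 2.2 (expected range 1.6 to 2.8).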

Compound 4, distribution coefficient: 2.7
Estimate against measurement, compound 4: 0.50 log units below, and the stated range covers the measured number.
By their numbers in this assay, from the lowest: compound 2; then compounds 1 and 3 (each within the scatter of the next); then compound 4.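

Among these compounds, at this position, on an aromatic carbon para to a large group, the earlier compounds offered no pair differing in one place. In this assay, among the compounds shown here, the exchange of 4-(dimethylcarbamoyl)-1H-pyrazol-1-yl for the fused group gives a number 2.20 log units higher from compound 2 to compound 4 (beyond the scatter) and this large step is the first reading of a change at this place. No measurement shown here accounts for the size of this step.

The change removes the dimethylcarbamoyl group and adds the six-membered non-aromatic ring together, so the compounds shown do not separate the two. As far as these compounds go, how a pyrazole bearing only a nitrile, a methyl or an amine would read at this place remains open.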